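The compounds below may be only part of what the source reports. "The series", "measured", "known", "first", "only" and "open" are said of these compounds alone.

Measured compounds:
- Compound 1 `Cc1nnc(SCC(=O)c2ccc(Cl)cc2)n1N1C(=O)c2ccccc2C1=O`. In a functional assay on HepG2 cells (Homo sapiens) for cytotoxicity, read by MTT assay, with a stated time of 48 h (a higher number here means a weaker inhibitor, a lower number a stronger inhibitor), compound 1 gives > 200000 nM, which is a limit of the assay and not a number.
- Compound 2 `C=CCSc1nnc(CC)n1N1C(=O)c2ccccc2C1=O`. In this assay compound 2 gives > 200000 nM, again a limit of the assay rather than a number.

Compound 2 therefore stands at the edge of what this assay can report: its value is a limit, and the same holds for every value shown, as the limit of > 200000 nM in this assay, at which 2 of the 2 values shown sit, records. Among the compounds with values here, no step between measured compounds is available, so nothing in the numbers tells how a change at the sulfur-bound chain shifts the read-out.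

Compound 3 `CCc1nnc(SC)n1N1C(=O)c2ccccc2C1=O` differs from compound 2 in one place: hydrogen in place of vinyl on a saturated chain carbon bound to a sulfur, read one bond further out as allyl to methyl, or allylsulfanyl to methylsulfanyl. With both shown values sitting at the limit, the expected step in this assay is none beyond the scatter, in either direction. Compound 3 is expected to sit at or beyond that same limit, estimated at 250000 nM within 100000 nM to 700000 nM, an expected step that the limit leaves unreadable from compound 2 to compound 3.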

Compound 3, half-maximal inhibitory concentration: > 200000 nM
Compound 3 was reported as a limit; the forecaster's own chance of this, stated with the estimate: 85%; the middle value is on the limit's open side.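

Compound 2 and compound 3 both stand at a limit of the assay rather than at a number in this assay, so no step can be read between them: the limit of > 200000 nM in this assay, at which 3 of the 3 values shown sit.

The compounds shown leave open how the change from allylsulfanyl to methylsulfanyl shifts the read-out, and whether any related compound would give a number rather than a limit in this assay.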